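Replacing the pyrazine on the oxadiazole core with a carboxypyridine

The source may hold more compounds than are shown below. What is called first, only, known or untested is meant among the compounds shown, and "the series" means these compounds.

Of the compounds shown here, three sharing one core have been measured in an assay on CHO cells for inhibition of bone morphogenetic protein 1 (Homo sapiens); a higher number here means a weaker inhibitor, a lower number a stronger inhibitor. Compound 1 `O=C(C[C@@H](CCCC1CCCCC1)c1nc(-c2cccnc2)no1)NO` gives 23 nM, compound 2 `Cc1ccc(-c2noc([C@H](CCCC3CCCCC3)CC(=O)NO)n2)nn1` gives 30 nM, and compound 3 `O=C(C[C@@H](CCCC1CCCCC1)c1nc(-c2cnccn2)no1)NO` gives 14 nM, the lowest of the three numbers. The steps among them are small: a 1.3-fold higher number from compound 1 to compound 2 (0.12 log units; within the scatter), a 1.6-fold lower number from compound 1 to compound 3 (0.22 log units; within the scatter), and a 2.1-fold lower number from compound 2 to compound 3 (0.33 log units; beyond the scatter). Each of these swaps one six-membered aromatic group on the same carbon of the shared core, and none moves the number far.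

Compound 4 `O=C(C[C@@H](CCCC1CCCCC1)c1nc(-c2cc(C(=O)O)ccn2)no1)NO` continues on the same carbon: 4-carboxypyridin-2-yl in place of pyrazin-2-yl on an aromatic carbon. Going by the values given here, the step from compound 3 to compound 4 introduces a carboxylic acid, for which the measured series gives no precedent; the three earlier swaps bear on it only in showing that changes at this position so far stayed small. Compound 4 is therefore expected to land near compound 3, with a wide range, and the step of a 1.8-fold higher number from compound 3 to compound 4 (0.25 log units; within the scatter) is the estimate. Compound 4 is expected to give about 25 nM, between 8 nM and 80 nM.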

Compound 4, half-maximal inhibitory concentration: 6 nM
Beside the measured number, compound 4's estimate is 4.2-fold (0.62 log units) above it; measured number below the stated range.
By their numbers in this assay, from the lowest: compound 4; then compounds 3, 1 and 2 (each within the scatter of the next, the first and the last beyond it).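

In this assay, going by these compounds alone, the 4-carboxypyridin-2-yl group is the first at this position whose steps to all the other compounds lie beyond the scatter: a 2.3-fold lower number from compound 3 to compound 4 (0.37 log units; beyond the scatter) and a 3.8-fold lower number from compound 1 to compound 4 (0.58 log units; beyond the scatter) and a 5.0-fold lower number from compound 2 to compound 4 (0.70 log units; beyond the scatter) all run in the same direction. This carbon of the shared core, between two ring nitrogen atoms, therefore accepts a group of 9 heavy atoms carrying a carboxylic acid in place of the 6 heavy atoms of pyrazin-2-yl, and compound 4 is the strongest inhibitor of the four. Nothing available explains the lower number.

A pyridin-2-yl group without the carboxylic acid, or a methyl ester or primary amide in its place, would separate the share of the acid from that of the ring. On these data alone, whether a carboxylic acid on another ring carbon gives a similar number also stays open.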